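The source may report more compounds than this note shows. Statements on the series, on what has been measured and on what is new or still open speak of the compounds shown alone.

Measured so far:
- Compound 1, `Fc1ccc(Cn2cncc2CNc2ccc(-c3nc4ccccc4s3)c(-c3ccccc3)c2)c(F)c1`: > 1000 nM
- Compound 2, `CCc1ccc(Cn2cncc2CNc2ccc(-c3nc4ccccc4s3)c(-c3ccccc3)c2)cc1`: > 1000 nM
- Compound 3, `CS(=O)(=O)c1ccc(Cn2cncc2CNc2ccc(-c3nc4ccccc4s3)c(-c3ccccc3)c2)cc1`: > 1000 nM

In a toxicity assay on NIH3T3 cells (Mus musculus) for cytotoxicity, read by resazurin assay (on this read-out lower numbers stand for an effect already at smaller amounts and higher numbers for an effect only at larger amounts of compound), compound 1 gives > 1000 nM, and this is a limit of the assay, not a number. The same holds for compound 2 and for compound 3, each of which is reported only as a limit. Thus all three measured compounds sit together at the limit of > 1000 nM in this assay, at which 3 of the 3 values shown sit, and the steps between them, a step that the two limits leave unreadable from compound 1 to compound 2, a step that the two limits leave unreadable from compound 1 to compound 3 and a step that the two limits leave unreadable from compound 2 to compound 3, cannot be read in size or direction.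

The unmeasured compound 4, `COC(=O)c1ccc(NCc2cncn2Cc2ccc(F)cc2F)cc1-c1ccccc1`, differs from compound 1 in one place: methoxycarbonyl in place of 1,3-benzothiazol-2-yl on an aromatic carbon. Going by the values given here, none of the measured steps touches this position; they all alter the group on the saturated chain carbon bound to an aromatic nitrogen, and all remain at the limit. So there is no measured step that bears on the change from compound 1 to compound 4. Among the compounds with values here, for compound 4 the step is therefore only estimated, as a step that the limit leaves unreadable from compound 1 to compound 4, with no measured step to give it a direction. The expectation for compound 4 rests only on the fact that every measured compound sits at the limit, so compound 4 is estimated at 3000 nM, with a range from 1000 nM to 30000 nM, most likely again reported only as a limit.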

Compound 4, half-maximal effective concentration: > 1000 nM
Compound 4: no number, only a limit; the forecaster's own chance of this, stated with the estimate: 80%; the middle value does not contradict the limit.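

In this assay compound 4 gives > 1000 nM, which is a limit of the assay and not a number. Compound 1 is also reported only as a limit, so the step between compound 1 and compound 4 cannot be read. The compounds shown leave open whether methoxycarbonyl in place of 1,3-benzothiazol-2-yl changes the cytotoxicity at all.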